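The source may hold more compounds than are shown below. What is called first, only, known or untested is meant among the compounds shown, and "the series" means these compounds.

Measured in a functional assay on MOLT-4 cells (Homo sapiens) for cytotoxicity, read by sulforhodamine B assay, with a stated time of 48 h, tested at 10 uM; a lower number here means a stronger effect, a higher number a weaker effect of the compound at the concentration tested:
compound 1, `COc1cc(-c2cc(/C=C/C(=O)c3ccc(N)cc3)[nH]n2)cc(OC)c1OC`, gives -5%
compound 2, `COc1ccc(C(=O)/C=C/c2cc(-c3cc(OC)c(OC)c(OC)c3)n[nH]2)cc1OC`, gives -30%
compound 3, `COc1ccc(C(=O)/C=C/c2cc(-c3cc(OC)c(OC)c(OC)c3)n[nH]2)cc1`, gives -20%

Compound 4, `COc1ccc(-c2cc(/C=C/C(=O)c3ccc(N)cc3)[nH]n2)cc1OC`, has not yet been measured in this assay. It arises from compound 1 by hydrogen in place of methoxy on an aromatic carbon. The same kind of change has already been measured once, between compound 2 and compound 3: hydrogen in place of methoxy on an aromatic carbon, which gave a number 10 percentage points higher from compound 2 to compound 3 (within the scatter). The surroundings are not quite identical, since in compound 1 the leaving methoxy is also meta to a second methoxy group, so this is the same kind of change rather than the same change. The two pairs also sit on different cores, and the cores differ by 4-aminophenyl in place of 3,4-dimethoxyphenyl on a carbonyl carbon. Among the three measured compounds, compound 1 stands highest, with a number 15 percentage points lower from compound 1 to compound 3 (beyond the scatter) and a number 25 percentage points lower from compound 1 to compound 2 (beyond the scatter).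

Because the measured step of a number 10 percentage points higher from compound 2 to compound 3 (within the scatter) stayed within the scatter, the step from compound 1 to compound 4 is expected to be similarly small, a number 7 percentage points higher from compound 1 to compound 4 (within the scatter). Compound 4 is therefore estimated at 2%, likely between -15% and 20%.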

Compound 4, a percentage reported as activity, at one concentration (the size of the read-out at that concentration, not a potency): 6%
Estimate against measurement, compound 4: 4 percentage points below; measured number inside the range.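

In this assay, hydrogen in place of methoxy on an aromatic carbon gives a number 11 percentage points higher from compound 1 to compound 4 (beyond the scatter). Set beside the earlier case, the change carries over from one core to the other with nearly the same size, even though only the new step is printed as beyond the scatter: the same change on two cores in this assay, a number 10 percentage points higher (within the scatter) from compound 2 to compound 3 and a number 11 percentage points higher (beyond the scatter) from compound 1 to compound 4, 1 percentage points apart, within the scatter of two such steps This agreement rests on just two pairs, in which the methoxy leaves different surroundings, and each read-out comes from a single concentration, so it does not show that the step would be the same on a third core, nor does it explain why the two steps match.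

The compounds shown leave open what a hydroxyl group, a fluorine atom or the longer ethoxy chain would do on that same aromatic carbon. They also leave open whether the step would keep its size on a core carrying a carboxylic acid in place of the amino group of compound 1.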